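Bromo in place of fluoro: the next step

A few compounds are considered here, and "the series" means these few. Any claim that something is new, unique, unknown or untested is made for them only; others in the source may bear on it.

Measured in a functional assay (aorta) with Oryctolagus cuniculus as the target (on this read-out higher numbers stand for weaker inhibition and lower numbers for stronger inhibition), as follows:
Compound 1 `CC1=C(C(CCCCCC(=O)O)c2ccccc2)C(=O)c2ccccc2C1=O` gives 240 nM
Compound 2 `CC1=C(C)C(=O)C(C(CCCCCC(=O)O)c2ccccc2C)=C(C)C1=O` gives 3200 nM
Compound 3 `CC1=C(C)C(=O)C(C(CCCCCC(=O)O)c2ccc(F)cc2)=C(C)C1=O` gives 48 nM

Among these three, compound 3 has the lowest number, and its gaps to compound 1 and compound 2 both lie beyond the usual scatter. Compound 4 `CC1=C(C)C(=O)C(C(CCCCCC(=O)O)c2ccc(Br)cc2)=C(C)C1=O` has not yet been measured. It differs from compound 3 by bromo in place of fluoro on an aromatic carbon and the change reads 4-fluorophenyl to 4-bromophenyl.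

Within the data shown here, the one measured step that bears on this is a 67-fold lower number from compound 2 to compound 3 (1.82 log units; beyond the scatter) and it is large, so a change of the aromatic group can move the number strongly in this assay for these compounds. Among the measured compounds shown here, that step, however, brought in the 4-fluorophenyl group from a different group, and no measured pair puts bromo in place of fluoro. For this exchange of bromo for fluoro on an aromatic carbon, no step beyond the scatter is expected, and the expectation starts from compound 3 at 48 nM with a wide margin on either side. The estimated step is a 1.3-fold higher number from compound 3 to compound 4 (0.10 log units; within the scatter) and it stays small. For compound 4 the estimated value is 60 nM with an expected range from 20 nM to 200 nM in this read-out.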

Compound 4, half-maximal inhibitory concentration: 1700 nM
Beside the measured number, compound 4's estimate is 28-fold (1.45 log units) below it; measured number above the stated range.
By their numbers in this assay, from the lowest: compound 3; then compound 1; then compounds 4 and 2 (each within the scatter of the next).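

Bromo and fluoro count alike under the computed comparison, each a single heavy atom with no donor, acceptor or charge, yet in this assay this exchange on an aromatic carbon para to a large group gives a 35-fold higher number from compound 3 to compound 4 (1.55 log units; beyond the scatter) and so stands as a large step. The earlier compounds had shown a large step only for a change of the whole aromatic group, whereas here one atom at this place is enough, so the 4-fluorophenyl to 4-bromophenyl change is far from a neutral swap in this assay. The other new comparison gives a 1.9-fold lower number from compound 2 to compound 4 (0.27 log units; within the scatter) and lies within the scatter, so this assay does not separate the 4-bromophenyl compound from the 2-methylphenyl compound, and of the three aromatic groups on this core only 4-fluorophenyl stands apart.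

The compounds shown leave open whether chloro or methoxy on the same aromatic carbon would fall with compound 3 or with compound 4, and whether the same exchange would act alike on the core of compound 1. Nothing at hand speaks to the reason for this large step.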